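Hydroxy on the methoxy ring of compound 2

The source may report more compounds than this note shows. Statements on the series, on what has been measured and on what is new or still open speak of the compounds shown alone.

In a functional assay on HL-60 cells (Homo sapiens) for cytotoxicity, read by WST assay, with a stated time of 48 h (on this read-out lower numbers stand for an effect already at smaller amounts and higher numbers for an effect only at larger amounts of compound), compound 1 `O=C1OC[C@H](Cc2cccc(O)c2)[C@H]1Cc1ccc(Cl)c(Cl)c1` gives (48000 nM) and compound 2 `COc1cccc(C[C@H]2COC(=O)[C@@H]2Cc2ccc(Cl)c(Cl)c2)c1` gives (34000 nM). For the measured compounds named here, compound 2 therefore stands within the scatter of compound 1, the only other measured compound. Compound 3 `COc1cc(C[C@H]2COC(=O)[C@@H]2Cc2ccc(Cl)c(Cl)c2)ccc1O` differs from compound 2 by hydroxy in place of hydrogen on an aromatic carbon, with hydroxy in place of hydrogen on an aromatic carbon, ortho to a methoxy group and para to a large group. Going by the values given here, the one measured step, a 1.4-fold lower number from compound 1 to compound 2 (0.15 log units; within the scatter), is methyl in place of hydrogen on an oxygen on an aromatic ring. It stayed small but concerns a different change, so it bears on this one only indirectly. Among the compounds with values here, no measured step shows hydroxy entering on an aromatic carbon. No clear direction is therefore expected in this assay, and the expected step, a 1.1-fold lower number from compound 2 to compound 3 (0.05 log units; within the scatter), stays within the scatter. The estimate for compound 3 is 30000 nM, with an expected range from 10000 nM to 80000 nM.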

Compound 3, half-maximal effective concentration: 36000 nM
Beside the measured number, compound 3's estimate is 1.2-fold (0.08 log units) below it; low and high end bracket the measured number.
By their numbers in this assay, from the lowest: compounds 2, 3 and 1 (each within the scatter of the next).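

In this assay, hydroxy in place of hydrogen on an aromatic carbon, ortho to a methoxy group and para to a large group, goes with a 1.1-fold higher number from compound 2 to compound 3 (0.02 log units; within the scatter). For the compounds shown here, compounds 1 and 2 carry only hydrogen at this position, so this is the only reading of a substituent there, and it shows that this hydroxy leaves compound 3 within the scatter of compound 2. No measurement at hand offers an explanation for this result.

As far as these compounds go, it remains open whether an amine or a carboxylic acid on the same aromatic carbon would also stay within the scatter of compound 2. From the compounds shown here alone, it is equally open whether an ethoxy group in place of the methoxy group would change the reading in this assay when this hydroxy is present.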